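Two Methoxy Groups Replace a Single Fluorine

This account rests on a few compounds, and the source may have more. Where it says the series, first, only, none or still open, it means among the compounds named here.

Compound 2 `Fc1ccc(C2CC(c3ccccc3)=NN2c2ccc(-c3ccccc3)nn2)cc1` carries a 4-fluorophenyl group on a saturated ring carbon of the shared core. In a functional assay on A549 cells (Homo sapiens) for antiproliferative activity, read by MTT assay, with a stated time of 24 h (on this read-out lower numbers stand for stronger inhibition and higher numbers for weaker inhibition), compound 2 gives 89200 nM. Among the compounds with values here, that is the lowest of the three numbers measured so far, but only just: compound 1 `Clc1ccc(C2CC(c3ccccc3)=NN2c2ccc(-c3ccccc3)nn2)cc1` gives 100000 nM and compound 3 `COc1ccc(C2CC(c3ccccc3)=NN2c2ccc(-c3ccccc3)nn2)cc1` gives 91700 nM, and all three lie within the scatter of each other, so no order among them can be claimed. Compound 4 `COc1ccc(C2CC(c3ccccc3)=NN2c2ccc(-c3ccccc3)nn2)c(OC)c1` has not yet been measured; it differs from compound 2 by 2,4-dimethoxyphenyl in place of 4-fluorophenyl on a saturated ring carbon.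

The measured steps each swap one group on an aromatic carbon of that ring: a 1.1-fold lower number from compound 1 to compound 2 (0.05 log units; within the scatter), a 1.1-fold lower number from compound 1 to compound 3 (0.04 log units; within the scatter) and a 1.0-fold higher number from compound 2 to compound 3 (0.01 log units; within the scatter). None of them moved the number beyond the scatter, so exchanging the group on that aromatic carbon has so far made no visible difference. Within the data shown here, no measured pair compares a 2,4-dimethoxyphenyl group with anything, so what it brings is unknown. The expectation for compound 4 is therefore a step of a 1.0-fold lower number from compound 2 to compound 4 (0.02 log units; within the scatter), meaning no change beyond the scatter. Compound 4 is estimated at 85000 nM, with a range from 30000 nM to 150000 nM.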

Compound 4, half-maximal inhibitory concentration: 9560 nM
The estimate for compound 4 lay 8.9-fold (0.95 log units) above the measured number; measured number outside the range, below it.
By their numbers in this assay, from the lowest: compound 4; then compounds 2, 3 and 1 (each within the scatter of the next).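

Exchanging one group on the phenyl ring at this saturated ring carbon had changed nothing beyond the scatter, but in this assay adding a second methoxy group gives a 9.6-fold lower number from compound 3 to compound 4 (0.98 log units; beyond the scatter) and so shows that this ring can strongly affect the number. The other two comparisons point the same way, with 2,4-dimethoxyphenyl in place of 4-fluorophenyl giving a 9.3-fold lower number from compound 2 to compound 4 (0.97 log units; beyond the scatter) and the same group in place of 4-chlorophenyl giving a 10-fold lower number from compound 1 to compound 4 (1.02 log units; beyond the scatter), which leaves compound 4 with the lowest number of the four compounds. No measurement shown gives a reason for this drop.

Compound 4 has two methoxy groups, and the compounds shown cannot tell whether the added methoxy group would give the same drop without the other one or whether the pair is needed. On these data alone, it also remains open whether a hydroxy group, an amine or a longer chain such as ethoxy in place of either methoxy group would keep, extend or lose the lower number.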